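This account rests on a few compounds, and the source may have more. Where it says the series, first, only, none or still open, it means among the compounds named here.

Measured so far in a functional assay on SK-N-SH cells (Homo sapiens) for inhibition, read by MTT assay; a higher number here means a weaker inhibitor, a lower number a stronger inhibitor:
- compound 1 `O=C(CN1CCN(c2ccccc2F)CC1)Nc1ccc(C(=O)/C=C/c2cn(Cc3ccc(Br)cc3)nn2)cc1`: 12800 nM
- compound 2 `CC(C)(C)OC(=O)N1CCN(CC(=O)Nc2ccc(C(=O)/C=C/c3cn(Cc4ccc(Br)cc4)nn3)cc2)CC1`: 25800 nM
- compound 3 `CCCCCCCCn1cc(/C=C/C(=O)c2ccc(NC(=O)CN3CCN(c4ccc([N+](=O)[O-])cc4)CC3)cc2)nn1`: 51400 nM

Compound 3 stands highest of the three numbers in this assay; its gap to compound 2 lies within the scatter, its gap to compound 1 beyond it.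

The next compound, compound 4 `O=C(CN1CCN(c2ccc([N+](=O)[O-])cc2)CC1)Nc1ccc(C(=O)/C=C/c2cn(Cc3ccc(Br)cc3)nn2)cc1`, arises from compound 3 by one change: 4-bromophenyl in place of heptyl on a saturated chain carbon bound to an aromatic nitrogen. Within the data shown here, only one measured step exists, a 2.0-fold higher number from compound 1 to compound 2 (0.30 log units; within the scatter), and it concerns the substituent on the amine nitrogen in the ring, a different place from the one changed here. Among the measured compounds shown here, no measured step therefore bears directly on the change from compound 3 to compound 4. What the data do show is that compound 1 and compound 2, which both carry the 4-bromobenzyl group on the aromatic nitrogen, give lower numbers in this assay than compound 3, which carries the octyl chain; each of those pairs, however, differs in two places, so no single step can be read from them.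

On that basis a modest move toward lower numbers is expected for compound 4, of the size a 2.1-fold lower number from compound 3 to compound 4 (0.31 log units; beyond the scatter), with wide uncertainty. The estimated value for compound 4 in this assay is 25000 nM, within the range 9000 nM to 70000 nM.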

Compound 4, half-maximal inhibitory concentration: 26500 nM
Beside the measured number, compound 4's estimate is 1.1-fold (0.03 log units) below it; the range from low to high includes it.
By their numbers in this assay, from the lowest: compounds 1, 2, 4 and 3 (each within the scatter of the next, the first and the last beyond it).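

In this assay, among these compounds, the first single-place reading at this site is a 1.9-fold lower number from compound 3 to compound 4 (0.29 log units; within the scatter), for 4-bromophenyl in place of heptyl on a saturated chain carbon bound to an aromatic nitrogen, so the octyl to 4-bromobenzyl exchange gives no order between this pair. The lower numbers of compound 1 and compound 2 relative to compound 3 therefore cannot be assigned to this exchange alone, since those pairs differ in two places. On the amine nitrogen in the ring, 4-nitrophenyl in place of tert-butoxycarbonyl gives a 1.0-fold higher number from compound 2 to compound 4 (0.01 log units; within the scatter), whereas 4-nitrophenyl in place of 2-fluorophenyl gives a 2.1-fold higher number from compound 1 to compound 4 (0.32 log units; beyond the scatter), a modest step and the only one of the three beyond the scatter.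

Still open, as far as these compounds go, is whether a carboxylic acid, a primary amine or a longer chain on the saturated chain carbon, or an unsubstituted phenyl on the amine nitrogen in the ring, would shift the number by more than the scatter. No supporting measurement is available to account for any of these steps.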